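Swapping Methoxy for Fluoro: An Expected Step

A few compounds are considered here, and "the series" means these few. Any claim that something is new, unique, unknown or untested is made for them only; others in the source may bear on it.

Of the compounds shown here, two have so far been measured in an assay on isolated protein for inhibition of Indoleamine 2,3-dioxygenase 1 (Homo sapiens), read by colorimetric assay, with stated times of 10 min and 30 min, tested at 100 uM; on this read-out lower numbers stand for less inhibition and higher numbers for more inhibition at the one concentration tested (going by the name of the read-out). Compound 1 `COc1ccccc1-c1csc(=S)[nH]1` gives 53% in this assay, the highest of the two numbers shown. Compound 2 `FC(F)(F)c1ccc(-c2csc(=S)[nH]2)cc1` gives 37% in this assay, a number that lies lower than that of compound 1 by a gap beyond the usual scatter. Among the measured compounds shown here, no pair of measured compounds differs in only one place, so no single step within the measured set is known.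

Compound 3 `Fc1ccccc1-c1csc(=S)[nH]1` has not yet been measured. It differs from compound 1 in one place: fluoro in place of methoxy on an aromatic carbon. The change sits on an aromatic carbon of a six-membered aromatic ring of carbon only, ortho to a group of 6 heavy atoms.

For the measured compounds named here, nothing among the measured compounds shows the effect of this exchange directly. The account therefore expects a modest step, a number 11 percentage points lower from compound 1 to compound 3 (beyond the scatter), pointing downward rather than upward, though not clearly beyond the scatter. For compound 3 the estimate in this assay is 42%, with a range from 25% to 58%.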

Compound 3, a percentage reported as inhibition, at one concentration (the size of the read-out at that concentration, not a potency): 77%
Compound 3: middle estimate off by 35 percentage points, on the low side, outside the stated range (above it).
By their numbers in this assay, from the lowest: compound 2; then compound 1; then compound 3.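

In this assay, among the compounds shown here, fluoro in place of methoxy on an aromatic carbon of the six-membered ring, ortho to a group of 6 heavy atoms, gives a number 24 percentage points higher from compound 1 to compound 3 (beyond the scatter), the first single change that can be read in this set. The number in this assay is higher with fluoro, with 1 heavy atom and 0 hydrogen-bond acceptors, than with the methoxy, with 2 heavy atoms and 1 hydrogen-bond acceptor, on the same core. Nothing measured here accounts for the size or direction of this step, so the reason for it remains unknown.

From the compounds shown here alone, it remains open whether this rise is particular to fluoro or would also appear with another group on the same aromatic carbon, such as chloro, a hydroxyl or an amine. Also unsettled is whether fluoro would give a similar step elsewhere on the ring, and whether the difference seen at this single concentration would carry over to a true measure of potency.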